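Taking One Chloro Off a Dichlorophenyl Compound

A few compounds are considered here, and "the series" means these few. Any claim that something is new, unique, unknown or untested is made for them only; others in the source may bear on it.

So far two compounds sharing one core have been tested in a functional assay on Huh-7 cells (Homo sapiens) for cytotoxicity, read by CCK-8 assay, with a stated time of 72 h (a higher number here means a weaker inhibitor, a lower number a stronger inhibitor), and only one of them gave a number. Compound 1 (`COc1ccccc1/C=c1/[nH]c(=O)/c(=C\c2ccccc2OC)n(C)c1=O`) is recorded as "not active" (no number reported) with no figure attached. Going by the values given here, compound 2 (`COc1ccccc1/C=c1\c(=O)[nH]/c(=C/c2cccc(Cl)c2Cl)c(=O)n1C`) gives 300 nM as the only number available, so there is no second number to rank it against.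

Compound 3 (`COc1ccccc1/C=c1\c(=O)[nH]/c(=C/c2ccccc2Cl)c(=O)n1C`) differs from compound 2 by a single change (hydrogen in place of chloro on an aromatic carbon), hydrogen in place of chloro on an aromatic carbon, which turns 2,3-dichlorophenyl into 2-chlorophenyl. Among the compounds with values here, no measured pair shows what this swap does, so any expectation rests on thin evidence. The one contrast available is that compound 2 gives 300 nM while compound 1 gives "not active" (no number reported) in the same test, a reminder that a measurable number is not guaranteed in this small set.

In this assay the estimated move is a 2.7-fold higher number from compound 2 to compound 3 (0.43 log units; beyond the scatter) toward weaker inhibition, a modest step expected to lie just beyond the usual scatter. Compound 3 is expected at 800 nM within an estimated range from 200 nM to 4000 nM if it yields a number at all.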

Compound 3, half-maximal inhibitory concentration: 300 nM
Beside the measured number, compound 3's estimate is 2.7-fold (0.43 log units) above it, within the range that was stated.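

In this assay the swap of hydrogen for chloro, which turns 2,3-dichlorophenyl into 2-chlorophenyl, reads no change at the digits printed from compound 2 to compound 3 (within the scatter) and so this chloro, on the aromatic carbon ortho to a chloro group, can go with no visible effect on the read-out. A measurable number therefore does not depend on this chloro being present, and the sharp contrast in this small set lies elsewhere: compound 1 is recorded as "not active" (no number reported) in the same test, and it carries a methoxy group where compound 3 keeps its single chloro. Nothing measured here gives a reason why the two chlorine-bearing compounds read alike.

Still open, on these data alone, is what the remaining chloro contributes on its own, for example whether a plain phenyl ring with hydrogen in its place would still give a number. Also open, as far as these compounds go, is how the position freed in compound 3 would respond to something other than hydrogen or chloro, such as an amine, a carboxylic acid or a longer chain.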